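The compounds below may be only part of what the source reports. "The series", "measured", "known", "first", "only" and "open" are said of these compounds alone.

Measured in a functional assay on SNB-75 cells (Homo sapiens) for inhibition, read by sulforhodamine B assay, with a stated time of 48 h; a lower number here means a stronger inhibitor of growth, a higher number a weaker inhibitor of growth:
- compound 1 `COc1cc(C)cc(-c2c(-c3ccnc(-c4ccc(C(C)=O)cc4)c3)cnn2CC#N)c1`: 2080 nM
- compound 2 `Cc1cc(O)cc(-c2nn(CC#N)cc2-c2ccnc(-c3ccc(Oc4ccccc4)cc3)c2)c1`: 3820 nM
- compound 3 `Cc1cc(O)cc(-c2nn(CC#N)cc2-c2ccnc(-c3ccc(N(C)C)cc3)c2)c1`: 1860 nM

Compound 1 stands second highest of the three numbers in this assay; its gap to compound 3 and its gap to compound 2 both lie within the scatter, so nothing separates it from either neighbour. Among the measured compounds shown here, the one step beyond the scatter in this set is a 2.1-fold lower number from compound 2 to compound 3 (0.31 log units; beyond the scatter), on the hydroxy-bearing partner.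

Compound 4 `COc1cc(C)cc(-c2c(-c3ccnc(-c4ccc(N(C)C)cc4)c3)cnn2CC#N)c1` is reached from compound 1 by dimethylamino in place of acetyl on an aromatic carbon. For the measured compounds named here, no measured pair covers acetyl leaving; the step from compound 2 to compound 3 shows dimethylamino entering, but in place of phenoxy and on the other partner ring. Compound 3 carries the same dimethylamino end and gives 1860 nM, close to compound 1. Taken together, a small lowering or no step beyond the scatter is expected in this assay.

Compound 4 is therefore estimated at 1500 nM (range 700 nM to 3500 nM), an expected step of a 1.4-fold lower number from compound 1 to compound 4 (0.14 log units; within the scatter).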

Compound 4, concentration for 50% growth inhibition: 69.4 nM
For compound 4 the middle estimate is 22-fold (1.33 log units) above the measured one; the measured number lies below the stated range.
By their numbers in this assay, from the lowest: compound 4; then compounds 3, 1 and 2 (each within the scatter of the next, the first and the last beyond it).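

In this assay, the place para to a large group on the phenyl ring proves highly sensitive on the core of compound 1: exchanging acetyl for dimethylamino, with the heavy-atom count unchanged at 3, gives a 30-fold lower number from compound 1 to compound 4 (1.48 log units; beyond the scatter), well beyond the modest 2.1-fold lower number from compound 2 to compound 3 (0.31 log units; beyond the scatter) seen earlier when dimethylamino replaced phenoxy. Compound 3 carries the same 4-(dimethylamino)phenyl end but differs from compound 4 in more than one place, so that pair does not show how much of the effect belongs to this end alone. No measurement at hand bears on the origin of the step.

Open, from the compounds shown here alone, is how an unsubstituted amino group, diethylamino or morpholine would read at this place on the core of compound 4. Also open, going by these compounds, is whether the methoxy group of compound 4 contributes, which a matched hydroxy partner would test.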